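Compound 2 to compound 3: swapping the side chain

A few compounds are considered here, and "the series" means these few. Any claim that something is new, unique, unknown or untested is made for them only; others in the source may bear on it.

Measured in an ADME assay on MRC5 cells (Homo sapiens) for cytotoxicity, read by fluorescence and resazurin assay, with a stated time of 3 days (a higher number here means that more compound is needed for the effect, a lower number that less compound is needed), so far
compound 1 `O=C1C=CC(O)(c2cc3ccccc3n2S(=O)(=O)c2ccccc2)C=C1` gives 110 nM
compound 2 `CN1CCN(CCCc2ccc(S(=O)(=O)n3c(C4(O)C=CC(=O)C=C4)cc4ccccc43)cc2)CC1` gives 50 nM

Compound 2 holds the lower of these two numbers. The change to compound 3 `CS(=O)(=O)c1ccc(S(=O)(=O)n2c(C3(O)C=CC(=O)C=C3)cc3ccccc32)cc1` is methylsulfonyl in place of 3-(4-methylpiperazin-1-yl)propyl on an aromatic carbon and it is methylsulfonyl in place of 3-(4-methylpiperazin-1-yl)propyl on an aromatic carbon. Going by the values given here, only one measured step bears on it: a 2.2-fold lower number from compound 1 to compound 2 (0.34 log units; beyond the scatter), where that same 3-(4-methylpiperazin-1-yl)propyl replaced hydrogen. That step is modest but beyond the scatter. Among the compounds with values here, no measured compound shows what methylsulfonyl does at this place, so the expectation remains loose. A step of similar size toward a higher number is expected in this assay, estimated as a 2.0-fold higher number from compound 2 to compound 3 (0.30 log units; within the scatter) and possibly lost in the scatter. Compound 3 is expected at 100 nM, with an estimated range from 35 nM to 280 nM for now.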

Compound 3, half-maximal effective concentration: 39 nM
The estimate for compound 3 lay 2.6-fold (0.41 log units) above the measured number; low and high end bracket the measured number.
By their numbers in this assay, from the lowest: compounds 3 and 2 (each within the scatter of the next); then compound 1.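

In this assay, methylsulfonyl in place of 3-(4-methylpiperazin-1-yl)propyl gives a 1.3-fold lower number from compound 2 to compound 3 (0.11 log units; within the scatter), so the piperazine ring and its nitrogens are not needed to keep the number in this range. Against the unsubstituted compound, methylsulfonyl gives a 2.8-fold lower number from compound 1 to compound 3 (0.45 log units; beyond the scatter), so two quite different groups on this aromatic carbon now both sit apart from hydrogen, and none of the three compounds goes against that. Nothing available gives a reason for this result.

From the compounds shown here alone, it remains open whether a carboxylic acid, a simple amine or a plain methyl group on this carbon would follow the same pattern. Also open, going by these compounds, is whether the number would move further with any group here, or whether the shared core sets a floor for this series.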